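Replacing the methoxyphenyl ring: a fluorophenyl variant

The compounds below may be only part of what the source reports. "The series", "measured", "known", "first", "only" and "open" are said of these compounds alone.

Compound 1 `COc1ccc(-c2cn3ccnc3c(-c3ccc4ncn(C5CCCCC5)c4c3)n2)cc1` gives 82.8% in a functional assay on MOLT-4 cells (Homo sapiens) for inhibition, read by sulforhodamine B assay, with a stated time of 48 h, tested at 10 uM (a lower number here means less inhibition, a higher number more inhibition at the concentration tested (going by the name of the read-out)), the highest of the three numbers measured. Compound 2 `O=Cc1ccc(-c2cn3ccnc3c(-c3ccc4ncn(C5CCCCC5)c4c3)n2)cc1` gives 58.7% in this assay, and compound 3 `c1cn2cc(-c3ccsc3)nc(-c3ccc4ncn(C5CCCCC5)c4c3)c2n1` gives 30% in this assay. Compound 4 `Fc1ccccc1-c1cn2ccnc2c(-c2ccc3ncn(C4CCCCC4)c3c2)n1` has not yet been measured; it differs from compound 1 by 2-fluorophenyl in place of 4-methoxyphenyl on an aromatic carbon. Among the compounds with values here, two measured steps bear on this change. In this assay, a number 24.1 percentage points lower from compound 1 to compound 2 (beyond the scatter), and a number 52.8 percentage points lower from compound 1 to compound 3 (beyond the scatter). Both changes to the 4-methoxyphenyl of compound 1 lowered inhibition, so for compound 4 a decrease beyond the scatter is expected, likely smaller than the full ring exchange but more than the scatter. For compound 4 the expected step is a number 37.8 percentage points lower from compound 1 to compound 4 (beyond the scatter). Compound 4 is estimated at 45%, with a range from 20% to 72%.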

Compound 4, a percentage reported as inhibition, at one concentration (the size of the read-out at that concentration, not a potency): 22.5%
Compound 4: the middle estimate sits 22.5 percentage points above what was measured; the measured number falls inside the stated range.
By their numbers in this assay, from the lowest: compounds 4 and 3 (each within the scatter of the next); then compound 2; then compound 1.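

Keeping a phenyl ring at this position does not by itself preserve inhibition in this assay: 2-fluorophenyl gives a large loss (a number 60.3 percentage points lower from compound 1 to compound 4 (beyond the scatter)) and also falls clearly short of 4-formylphenyl (a number 36.2 percentage points lower from compound 2 to compound 4 (beyond the scatter)). It cannot be separated from the non-phenyl thiophen-3-yl (a number 7.5 percentage points lower from compound 3 to compound 4 (within the scatter)), so the phenyl ring alone gives no advantage over thiophen-3-yl. No measurement here explains these losses.

The compounds shown leave open whether the loss follows the fluorine or its place on the ring, since the one change both removes methoxy and adds 2-fluoro. 4-Fluorophenyl, 2-methoxyphenyl or 4-aminophenyl would help separate these possibilities.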